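Cytotoxicity notes on the shared core series

The source may report more compounds than this note shows. Statements on the series, on what has been measured and on what is new or still open speak of the compounds shown alone.

Compound 1 `O=C(Nc1cc(-c2ccccn2)n[nH]1)N1CCC(c2ccc(F)cc2)CC1`: in an ADME assay on MRC5 cells (Homo sapiens) for cytotoxicity, read by fluorescence and resazurin assay, with a stated time of 3 days (on this read-out higher numbers stand for lower toxicity in this test and lower numbers for higher toxicity in this test), compound 1 gives > 64000 nM, which is a limit of the assay and not a number.
Compound 2 `O=C(Nc1cc(-c2ccccn2)n[nH]1)N1CCN(c2ccc(F)cc2)CC1`: in this assay compound 2 gives > 64000 nM, again a limit.
Compound 3 `O=C(NCc1cccc(Cl)c1)Nc1cc(-c2ccccn2)n[nH]1`: in this assay compound 3 gives > 64000 nM, also a limit.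

Compound 1 thus stands at the limit, with no number of its own; the other two compounds sit at the same limit, as does every value shown (the limit of > 64000 nM in this assay, at which 3 of the 3 values shown sit). Among the compounds with values here, no pair among the measured compounds differs in one place, so no step has been measured, and the three values show only that none of them reaches a measurable cytotoxic concentration.

Compound 4 `O=C(Nc1cc(-c2ccccn2)n[nH]1)N1CCC(c2cccc(F)c2)CC1` is not yet measured. It differs from compound 1 by 3-fluorophenyl in place of 4-fluorophenyl on a saturated ring carbon.

With every measured compound at the limit, there is no basis for expecting the step from compound 1 to compound 4 to move the value in either direction; the expected step of a number no higher from compound 1 to compound 4 (the limit leaves the size open) is none beyond the scatter. Compound 4 is therefore expected to sit at or beyond the limit as well, with an estimate of 64000 nM and a range from 20000 nM to 200000 nM, most likely reported again as a limit.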

Compound 4, half-maximal cytotoxic concentration: > 64000 nM
Compound 4 ended at the assay's limit (the forecaster's own chance of this, stated with the estimate: 85%); the middle value lies on the limit itself.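

The step from compound 1 to compound 4 cannot be read, as both compounds stand at a limit of the assay and not at a number: the limit of > 64000 nM in this assay, at which 4 of the 4 values shown sit.

Left open is the concentration at which any of the four compounds becomes cytotoxic in this assay, and whether 3-fluorophenyl and 4-fluorophenyl differ there at all.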